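Working notes: metabolic stability, replacing the trifluoromethylcyclopropyl group

The source may report more compounds than this note shows. Statements on the series, on what has been measured and on what is new or still open speak of the compounds shown alone.

Half-lives measured in an ADME assay on microsomes from liver (Rattus norvegicus, strain Sprague-Dawley) for metabolic stability, read by HPLC, using NADPH, with stated times of 5 min and 60 min, tested at 10 uM; a higher number here means that the compound lasts longer, a lower number that the compound disappears faster:
- compound 1, `CS(=O)(=O)Nc1ccc(CNC(=O)c2ccc(C3(C(F)(F)F)CC3)cc2)c(Cl)c1`: 3.03 h
- compound 2, `CS(=O)(=O)Nc1ccc(CNC(=O)c2ccc(C34CC(C3)C4)cc2)c(Cl)c1`: 1.35 h
- compound 3, `CN(C)c1ccc(C(=O)NCc2ccc(NS(C)(=O)=O)cc2Cl)cc1`: 0.883 h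

Compound 1 holds the highest number of the three. Compound 2 follows with a 2.2-fold lower number from compound 1 to compound 2 (0.35 log units; beyond the scatter), and compound 3 with a 3.4-fold lower number from compound 1 to compound 3 (0.54 log units; beyond the scatter). Between the two lower compounds there is a 1.5-fold lower number from compound 2 to compound 3 (0.18 log units; within the scatter), so they cannot be ordered against each other.

Compound 4, `CC(C)Oc1ccc(C(=O)NCc2ccc(NS(C)(=O)=O)cc2Cl)cc1`, has not yet been run in this assay. Against compound 1 the change is isopropoxy in place of 1-(trifluoromethyl)cyclopropyl on an aromatic carbon. Among the compounds with values here, two measured steps bear on it, both leaving the 1-(trifluoromethyl)cyclopropyl group on the same aromatic carbon: the move to the bicyclic group gave a 2.2-fold lower number from compound 1 to compound 2 (0.35 log units; beyond the scatter), and the move to dimethylamino gave a 3.4-fold lower number from compound 1 to compound 3 (0.54 log units; beyond the scatter). Isopropoxy, like dimethylamino, brings no ring, and both measured replacements went downward beyond the scatter. A downward step of similar size is therefore expected, a 3.0-fold lower number from compound 1 to compound 4 (0.48 log units; beyond the scatter). Compound 4 is expected to give 1 h in this assay, with a range from 0.5 h to 2 h, the middle of which sits near the measured values of compound 2 and compound 3.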

Compound 4, half-life: 1.85 h
Compound 4: the middle estimate sits 1.9-fold (0.27 log units) below what was measured; measured number inside the range.
By their numbers in this assay, from the lowest: compounds 3, 2, 4 and 1 (each within the scatter of the next, the first and the last beyond it).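

In this assay the step of a 1.6-fold lower number from compound 1 to compound 4 (0.21 log units; within the scatter) gives the first replacement of 1-(trifluoromethyl)cyclopropyl at this position that stays within the scatter of it, so on this aromatic carbon a group with no ring and no fluorine can hold a half-life that cannot be told apart from that of compound 1. Within the data shown here, the two ringless groups also separate for the first time, with the step of a 2.1-fold higher number from compound 3 to compound 4 (0.32 log units; beyond the scatter) showing that isopropoxy and dimethylamino are not interchangeable here, while the step of a 1.4-fold higher number from compound 2 to compound 4 (0.14 log units; within the scatter) leaves compound 2 and compound 4 unordered. Nothing available here explains these differences.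

From the compounds shown here alone, it remains open whether the separation of isopropoxy from dimethylamino follows the oxygen or the branched chain, and methoxy or tert-butyl on the same aromatic carbon would bear on that. A plain cyclopropyl group would show how much of the number of compound 1 depends on the trifluoromethyl part.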